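Replacing the amine tail of compound 1 with a carboxyethyl group

This account rests on a few compounds, and the source may have more. Where it says the series, first, only, none or still open, it means among the compounds named here.

In a functional assay on HepG2 cells (Homo sapiens) for antiproliferative activity, read by MTT assay, with a stated time of 48 h (on this read-out higher numbers stand for weaker inhibition and lower numbers for stronger inhibition), compound 1 `CCn1c(C(=O)NCCCN(C)C)ccc1C(CC)(CC)c1ccc(OCCC(O)(CC)CC)c(C)c1` gives 110 nM, the lowest number among the three measured compounds. Compound 2 `CCN(CC)CCNC(=O)c1ccc(C(CC)(CC)c2ccc(OCCC(O)(CC)CC)c(C)c2)n1CC` gives 230 nM, and compound 3 `CCn1c(C(=O)N(C)CC(=O)O)ccc1C(CC)(CC)c1ccc(OCCC(O)(CC)CC)c(C)c1` gives 5710 nM. Compound 4 `CCn1c(C(=O)NC(C)C(=O)O)ccc1C(CC)(CC)c1ccc(OCCC(O)(CC)CC)c(C)c1` differs from compound 1 in one place: 1-carboxyethyl in place of 3-(dimethylamino)propyl on an amide-type nitrogen. Within the data shown here, the closest precedent is compound 3, whose change also brought a carboxy-bearing group onto the amide side of the shared core, and that gave a 52-fold higher number from compound 1 to compound 3 (1.72 log units; beyond the scatter) as well as a 25-fold higher number from compound 2 to compound 3 (1.39 log units; beyond the scatter). By contrast, a 2.1-fold higher number from compound 1 to compound 2 (0.32 log units; beyond the scatter) shows that exchanging one amine chain for another moved the number only modestly. A large rise in this assay is therefore expected for compound 4, a 36-fold higher number from compound 1 to compound 4 (1.56 log units; beyond the scatter). The estimate for compound 4 is 4000 nM, with a range from 1500 nM to 12000 nM.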

Compound 4, half-maximal inhibitory concentration: 1740 nM
Beside the measured number, compound 4's estimate is 2.3-fold (0.36 log units) above it; the measured number falls inside the stated range.
By their numbers in this assay, from the lowest: compound 1; then compound 2; then compound 4; then compound 3.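

Compound 4 keeps the amide hydrogen and carries a carboxylic acid, yet the amine tails still hold a clear lead: there is a 16-fold higher number from compound 1 to compound 4 (1.20 log units; beyond the scatter) and also a 7.6-fold higher number from compound 2 to compound 4 (0.88 log units; beyond the scatter) on the same shared core. The two acid tails are not interchangeable either, since (1-carboxyethyl)amino gives a 3.3-fold lower number from compound 3 to compound 4 (0.52 log units; beyond the scatter) on the carbonyl carbon. Nothing shown here explains these shifts.

Compound 3 and compound 4 differ in both the methyl group on the nitrogen and the branching of the chain, so the effect of each stays unseparated. On these data alone, a longer chain ending in a carboxylic acid, or a methyl ester in place of the acid, remains open.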